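This account rests on a few compounds, and the source may have more. Where it says the series, first, only, none or still open, it means among the compounds named here.

Working notes on the series.

Compound 1 `Nc1nc2c(c(-c3cccs3)cn2[C@@H]2O[C@H](CO)[C@@H](O)[C@H]2O)c(=O)[nH]1` carries a thiophen-2-yl group on the shared core. In a functional assay on HepG2 cells (Homo sapiens) for antiproliferative activity, read by XTT assay, with a stated time of 72 h (a lower number here means a stronger inhibitor, a higher number a weaker inhibitor), compound 1 gives only a limit, > 20000 nM. Compound 2 `CN(C)c1ncnc2c1c(-c1cccs1)cn2[C@@H]1O[C@H](CO)[C@@H](O)[C@H]1O` has a different core; the difference between the two cores is not broken down here. In this assay compound 2 likewise gives only a limit, > 20000 nM. Compound 3 `Nc1nc2c(c(-c3cc4ccccc4o3)cn2[C@@H]2O[C@H](CO)[C@@H](O)[C@H]2O)c(=O)[nH]1` is compound 1 with 1-benzofuran-2-yl in place of thiophen-2-yl on an aromatic carbon. In this assay compound 3 also gives only a limit, > 20000 nM. The step that the two limits leave unreadable from compound 1 to compound 3 therefore has no readable size, since both of its ends are limits. Every measured value sits at the same point: the limit of > 20000 nM in this assay, at which 3 of the 3 values shown sit.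

Compound 4 `CN(C)c1ncnc2c1c(-c1cc3ccccc3o1)cn2[C@@H]1O[C@H](CO)[C@@H](O)[C@H]1O` is compound 2 with 1-benzofuran-2-yl in place of thiophen-2-yl on an aromatic carbon. The place around this change is the same, word for word, as in the change from compound 1 to compound 3, so it is the same change made on the second core. Nothing measured separates the two cores in this assay, as compound 1 and compound 2 each give only a limit.

The expected step from compound 2 to compound 4 in this assay is a step that the limit leaves unreadable from compound 2 to compound 4, which, like the measured one, cannot be read against a limit. This rests on the fact that all three measured values are limits, because the limit of > 20000 nM in this assay, at which 3 of the 3 values shown sit, holds every compound shown. Compound 4 is therefore expected at 30000 nM, with a range from 10000 nM to 100000 nM, and most likely to be reported only as a limit.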

Compound 4, half-maximal inhibitory concentration: > 20000 nM
Compound 4: a limit, no number; the forecaster's own chance of this, stated with the estimate: 85%; the middle value lies beyond the limit too.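

In this assay compound 4 gives > 20000 nM, which is a limit and not a number. Compound 2 also gives only a limit, so no step can be read from compound 2 to compound 4. The series stays at a single point: the limit of > 20000 nM in this assay, at which 4 of the 4 values shown sit.

The compounds shown leave open how thiophen-2-yl and 1-benzofuran-2-yl, or the two cores, compare in this assay.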